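This account rests on a few compounds, and the source may have more. Where it says the series, first, only, none or still open, it means among the compounds named here.

Three compounds built on a shared core were examined in a functional assay on HepG2 cells (Homo sapiens) for antiproliferative activity, read by CCK-8 assay, with a stated time of 72 h, tested at 2 uM; a lower number here means a weaker effect, a higher number a stronger effect of the compound at the concentration tested. Compound 1 `CC1CCN(c2nc(Cl)nc3c2ncn3Cc2ccc(/C=C/C(=O)Nc3ccccc3N)cc2)CC1` gives 8.73%. Compound 2 `Nc1ccccc1NC(=O)c1ccc(Cn2cnc3c(Nc4cccc(OC(F)(F)F)c4)nc(Cl)nc32)cc1` gives 1.88%, and compound 3 `CCCCn1cnc2c(Nc3cccc(Cl)c3)nc(NCOCc3ccc(C(=O)Nc4ccccc4N)cc3)nc21` gives 30.6%. Among these, compound 1 and compound 2 lie within the scatter of each other, whereas compound 3 sits beyond the scatter above both of them.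

Compound 4 `Nc1ccccc1NC(=O)/C=C/c1ccc(Cn2cnc3c(NCc4ccccc4)nc(Cl)nc32)cc1` remains to be measured. It differs from compound 1 in one place: benzylamino in place of 4-methylpiperidin-1-yl on an aromatic carbon. For the measured compounds named here, no pair of measured compounds differing in a single place is available to guide the expectation, so the step of a number 3.3 percentage points higher from compound 1 to compound 4 (within the scatter) is estimated to be small and upward, if it reaches beyond the scatter at all. For compound 4 the estimate in this assay is 12%, with a range from 2% to 30%.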

Compound 4, a percentage reported as inhibition, at one concentration (the size of the read-out at that concentration, not a potency): 11.5%
For compound 4 the middle estimate is 0.5 percentage points above the measured one; measured number inside the range.
By their numbers in this assay, from the lowest: compounds 2, 1 and 4 (each within the scatter of the next); then compound 3.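

In this assay, for the compounds shown here, benzylamino in place of 4-methylpiperidin-1-yl on this aromatic carbon gives a number 2.8 percentage points higher from compound 1 to compound 4 (within the scatter), the first comparison here of compounds differing in one place. At this single concentration, the two groups therefore cannot be told apart, even though benzylamino brings a hydrogen-bond donor and an aromatic ring. No available evidence bears on this result. As far as these compounds go, whether morpholine or a simple primary amine at this position would reach beyond the scatter remains open. So does whether either group would behave the same with a longer chain on the ring nitrogen.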